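Propoxy for Methoxy: Expected Lower Number for Compound 4

The source may hold more compounds than are shown below. What is called first, only, known or untested is meant among the compounds shown, and "the series" means these compounds.

Going by the values given here, compound 3 `COc1cc(/C=C2\CCC/C(=C\c3cccc([N+](=O)[O-])c3)C2=O)cc(Br)c1OC` gives 13.9 ug/mL in a functional assay on MDA-MB-231 cells (Homo sapiens) for cytotoxicity, read by MTT assay (on this read-out higher numbers stand for weaker inhibition and lower numbers for stronger inhibition), the highest of the three numbers measured so far. Compound 1 `COc1cc(/C=C2\CCC/C(=C\c3ccccc3[N+](=O)[O-])C2=O)cc(Br)c1OC` gives 8.99 ug/mL in this assay, and the step of a 1.5-fold higher number from compound 1 to compound 3 (0.19 log units; within the scatter) lies within the scatter, so the two cannot be told apart. Compound 2 `CCCOc1c(Br)cc(/C=C2\CCC/C(=C\c3ccccc3[N+](=O)[O-])C2=O)cc1OC` gives 1.99 ug/mL, a number that stands beyond the scatter from compound 3. Compound 4 `CCCOc1c(Br)cc(/C=C2\CCC/C(=C\c3cccc([N+](=O)[O-])c3)C2=O)cc1OC` differs from compound 3 by ethyl in place of hydrogen on a saturated chain carbon bound to an oxygen on an aromatic ring. The same change has been measured once, as a 4.5-fold lower number from compound 1 to compound 2 (0.65 log units; beyond the scatter), a modest step beyond the scatter. A step of similar size and direction is therefore expected, a 4.5-fold lower number from compound 3 to compound 4 (0.65 log units; beyond the scatter). On that basis compound 4 is estimated at 3.1 ug/mL, with a range from 1.5 ug/mL to 6.5 ug/mL.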

Compound 4, half-maximal inhibitory concentration: 2.99 ug/mL
Compound 4: the middle estimate sits 1.0-fold (0.02 log units) above what was measured; the range from low to high includes it.
By their numbers in this assay, from the lowest: compounds 2 and 4 (each within the scatter of the next); then compounds 1 and 3 (each within the scatter of the next).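

With a 4.6-fold lower number from compound 3 to compound 4 (0.67 log units; beyond the scatter) in this assay, methoxy to propoxy is no longer a single case, and the step has the same size with either nitrophenyl group: the same change on two cores in this assay, a 4.5-fold lower number (0.65 log units; beyond the scatter) from compound 1 to compound 2 and a 4.6-fold lower number (0.67 log units; beyond the scatter) from compound 3 to compound 4, 1.0-fold (0.01 log units) apart, within the scatter of two such steps

The change from 2-nitrophenyl to 3-nitrophenyl, earlier seen only with methoxy, stays within the scatter with propoxy, at a 1.5-fold higher number from compound 2 to compound 4 (0.18 log units; within the scatter), so the two nitrophenyl groups cannot be told apart on either core: the same change on two cores in this assay, a 1.5-fold higher number (0.19 log units; within the scatter) from compound 1 to compound 3 and a 1.5-fold higher number (0.18 log units; within the scatter) from compound 2 to compound 4, 1.0-fold (0.01 log units) apart, within the scatter of two such steps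

The compounds shown leave open whether the number would keep falling with a longer chain such as butoxy. They also leave open how an amine at the end of the propoxy chain would read.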